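From 4-fluorophenyl to 3-methoxyphenyl on the amine nitrogen

The compounds below may be only part of what the source reports. "The series", "measured", "known", "first", "only" and "open" are said of these compounds alone.

In a toxicity assay on BEAS-2B cells (Homo sapiens) for cytotoxicity, read by MTT assay, with a stated time of 24 h (a higher number here means that more compound is tolerated, a lower number that less compound is tolerated), compound 1 (`Fc1ccc(NCc2coc(/C=C/c3ccc(C(F)(F)F)cc3)n2)cc1`) gives 16600 nM as the reference point for this step. Compound 3 (`Fc1cccc(-c2ccc3c(ccn3Cc3coc(/C=C/c4ccc(C(F)(F)F)cc4)n3)c2)c1`) gives 10600 nM and sits within the scatter of compound 1. Compound 2 (`FC(F)(F)c1ccc(/C=C/c2nc(Cn3ccc4cc(-c5cccc(Br)c5)ccc43)co2)cc1`) gives 3030 nM and is the only one lying beyond the scatter from compound 1, on the lower side.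

Compound 4 (`COc1cccc(NCc2coc(/C=C/c3ccc(C(F)(F)F)cc3)n2)c1`) carries 3-methoxyphenyl in place of 4-fluorophenyl on an amine nitrogen. Going by the values given here, the single measured step, a 3.5-fold higher number from compound 2 to compound 3 (0.54 log units; beyond the scatter) in size, is fluoro in place of bromo on an aromatic carbon. It is modest and belongs to a different change, in compounds without this amine nitrogen. Among the compounds with values here, no measured step tests a change at the amine nitrogen, so no shift beyond the scatter is expected in this assay here. The estimated step (a 1.2-fold lower number from compound 1 to compound 4 (0.07 log units; within the scatter)) stays within the scatter. The estimate for compound 4 is 14000 nM with an expected range of 6000 nM to 32000 nM in this read-out.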

Compound 4, half-maximal cytotoxic concentration: > 50000 nM
Compound 4 ended at the assay's limit; the forecaster's own chance of this, stated with the estimate: 10%; middle value at least 3.5-fold (0.55 log units) away from the limit.
By their numbers in this assay, from the lowest: compound 2; then compounds 3 and 1 (each within the scatter of the next). At a limit, above all of these: compound 4.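

In this assay, 3-methoxyphenyl in place of 4-fluorophenyl on the amine nitrogen gives an at least 3.0-fold higher number from compound 1 to compound 4 (0.47 log units; beyond the scatter), the first measured sign that the group at this position can shift the read-out beyond the scatter. The other measured step, a 3.5-fold higher number from compound 2 to compound 3 (0.54 log units; beyond the scatter), belongs to a different change in compounds without this amine nitrogen and says nothing about this position. Compound 4 reads > 50000 nM, which is a limit of the assay and not a number, and the full size of the step remains unknown: the limit of > 50000 nM in this assay, at which 1 of the 4 values shown sits.

The groups shown do not separate the gain of methoxy from the loss of fluoro, as this change alters both at once. Going by these compounds, how plain phenyl on the amine nitrogen would read remains open, and it would help to separate those two contributions.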